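A Methyl Change Repeated on a Second Core

The source may hold more compounds than are shown below. What is called first, only, known or untested is meant among the compounds shown, and "the series" means these compounds.

In a functional assay on PC-12 cells (Rattus norvegicus) for cytotoxicity, read by MTT assay, with stated times of 3 h and 2 h, tested at 10 uM (a lower number here means a weaker effect, a higher number a stronger effect of the compound at the concentration tested), compound 1 `O=C(CCCCC1CCSS1)NCc1cn(CCCOc2ccc3ccc(=O)oc3c2)nn1` gives 40%. Compound 2 `Cc1cc(=O)oc2cc(OCCCn3cc(CNC(=O)CCCCC4CCSS4)nn3)ccc12` differs from it by methyl in place of hydrogen on an aromatic carbon, and in this assay compound 2 gives 69.4%, the step being a number 29.4 percentage points higher from compound 1 to compound 2 (beyond the scatter). Compound 3 `O=C(CCCCC1CCSS1)NCc1cn(CCCCCOc2ccc3ccc(=O)oc3c2)nn1` has a core whose difference from the core of compound 1 is not broken down here; in this assay compound 3 gives 71.3%, a value within the scatter of that of compound 2. Compound 4 `Cc1cc(=O)oc2cc(OCCCCCn3cc(CNC(=O)CCCCC4CCSS4)nn3)ccc12` carries the same change relative to compound 3 that compound 2 carries relative to compound 1: methyl in place of hydrogen on an aromatic carbon. Because compound 3 already stands at 71.3%, a smaller step is expected from compound 3 to compound 4, a number 6.7 percentage points higher from compound 3 to compound 4 (within the scatter), than the earlier a number 29.4 percentage points higher from compound 1 to compound 2 (beyond the scatter). Compound 4 is therefore expected to give about 78%, estimated to fall between 62% and 92%.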

Compound 4, a percentage reported as activity, at one concentration (the size of the read-out at that concentration, not a potency): 66.3%
Compound 4: middle estimate off by 11.7 percentage points, on the high side; measured number inside the range.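

In this assay, going by these compounds alone, methyl in place of hydrogen on an aromatic carbon gives a number 5 percentage points lower from compound 3 to compound 4 (within the scatter), so on the core of compound 3 the change produces no step that can be told from the scatter. The change did not carry over in size from one core to the other: the same change on two cores in this assay, a number 29.4 percentage points higher (beyond the scatter) from compound 1 to compound 2 and a number 5 percentage points lower (within the scatter) from compound 3 to compound 4, 34.4 percentage points apart, beyond the scatter of two such steps. The step seen on the core of compound 1 therefore cannot be assumed on the core of compound 3, but two pairs do not show why the steps differ or how the change would behave on any further core.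

The compounds shown leave open whether ethyl, chlorine or trifluoromethyl on the same aromatic carbon would behave like methyl on either core. They also leave open whether a longer chain than that of compound 4 would alter the step.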